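Cytotoxicity notes on a phenolic series, three limits and one unknown

A few compounds are considered here, and "the series" means these few. Any claim that something is new, unique, unknown or untested is made for them only; others in the source may bear on it.

Measured so far:
compound 1, `C=C[C@@](C)(/C=C/c1ccc(O)cc1)CCC(=O)C(=C)C` — > 10000 nM
compound 2, `CC(C)=CCc1cc2c(cc1O)O[C@H](c1ccc(O)cc1)CC2=O` — > 10000 nM
compound 3, `CC(C)(O)[C@@H]1Oc2ccc(-c3coc4cc(O)ccc4c3=O)cc2[C@H]1O` — > 10000 nM

In a functional assay on K562 cells (Homo sapiens) for cytotoxicity, read by MTT assay, with a stated time of 48 h (a higher number here means a weaker inhibitor, a lower number a stronger inhibitor), compound 1 gives > 10000 nM, which is a limit of the assay and not a number. Compound 2 likewise gives > 10000 nM, again a limit. Compound 3 gives > 10000 nM, a limit as well. Compound 1 therefore stands nowhere in particular on these numbers: all three values sit at the limit of > 10000 nM in this assay, at which 3 of the 3 values shown sit, and no ordering among compounds 1, 2 and 3 can be read from them.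

Going by the values given here, no step between two measured compounds is available, so the move to compound 4, `C=C[C@@](C)(/C=C/c1ccc(O)cc1)CC[C@@H](O)C(C)(C)O`, rests on the structural change alone: 1,2-dihydroxy-2-methylpropyl in place of (1-methylethenyl)carbonyl on a saturated chain carbon, three bonds along the chain from two double-bonded chain carbons. What the three measured compounds show is that the shared limit is reached by quite different structures, and nothing in the data points to a gain in potency from this change.

For this assay the step is expected to be none beyond the scatter, with compound 4 most likely reported as a limit again; the expected step is a step that the limit leaves unreadable from compound 1 to compound 4. Compound 4 is estimated at 15000 nM, within 5000 nM to 50000 nM.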

Compound 4, half-maximal inhibitory concentration: > 10000 nM
Compound 4 was reported as a limit (the forecaster's own chance of this, stated with the estimate: 85%); the middle value does not contradict the limit.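

In this assay compound 1 and compound 4 are both reported only as limits, so no step can be read for the exchange of (1-methylethenyl)carbonyl for 1,2-dihydroxy-2-methylpropyl. The compounds shown leave open whether this change affects cytotoxicity at all, and how compounds 1, 2, 3 and 4 rank against one another.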